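Removing a Fluoro Group: Two Parallel Steps in Cytotoxicity

The compounds below may be only part of what the source reports. "The series", "measured", "known", "first", "only" and "open" are said of these compounds alone.

Measured compounds:
compound 1 `COc1ccc2c(/C=C(\C#N)C(=O)c3c[nH]c4cc(F)ccc34)c[nH]c2c1`: in a functional assay on MIA PaCa-2 cells (Homo sapiens) for cytotoxicity, read by WST assay, with a stated time of 24 h (on this read-out higher numbers stand for weaker inhibition and lower numbers for stronger inhibition), compound 1 gives > 50000 nM, a limit of the assay.
compound 2 `COc1ccc2c(/C=C(\C#N)C(=O)c3c[nH]c4ccccc34)c[nH]c2c1`: in this assay compound 2 gives 27500 nM.
compound 3 `COc1ccc(Cn2cc(/C=C(\C#N)C(=O)c3c[nH]c4cc(F)ccc34)c3ccccc32)cc1`: in this assay compound 3 gives > 50000 nM, a limit of the assay.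

Compound 1 and compound 2 differ in one place: hydrogen in place of fluoro on an aromatic carbon. That change brought an at least 1.8-fold lower number from compound 1 to compound 2 (0.25 log units; that floor lies within the scatter). Because compound 1 sits at the limit of > 50000 nM in this assay, at which 2 of the 3 values shown sit, only a floor for this step is known, and that floor lies within the scatter.

Compound 3 carries the same fluoro group on a different core; the difference between the two cores is not broken down here. Compound 4 `COc1ccc(Cn2cc(/C=C(\C#N)C(=O)c3c[nH]c4ccccc34)c3ccccc32)cc1` is the not yet measured partner of compound 3, and it differs from it by hydrogen in place of fluoro on an aromatic carbon. The place of the change reads the same for both pairs, so this is the same change, made a second time.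

For compound 4 in this assay the expected step is an at least 1.2-fold lower number from compound 3 to compound 4 (0.09 log units; that floor lies within the scatter), resting on the floor seen in an at least 1.8-fold lower number from compound 1 to compound 2 (0.25 log units; that floor lies within the scatter) and on compound 3 sitting at its limit with > 50000 nM. Compound 4 is thus expected to give about 40000 nM, with a range from 15000 nM to 100000 nM, and a real chance that only a limit is reported again.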

Compound 4, half-maximal inhibitory concentration: > 50000 nM
Compound 4: a limit, no number (the forecaster's own chance of this, stated with the estimate: 55%); middle value at least 1.2-fold (0.09 log units) from the limit.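

Going by these compounds alone, compound 3 and compound 4 both sit at a limit of this assay, not at a number, so no step for the change from fluoro to hydrogen can be read on this pair: the limit of > 50000 nM in this assay, at which 3 of the 4 values shown sit. The compounds shown leave open whether this change alters the number at all on the core of compound 3, and what values compound 3 and compound 4 would have.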